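A Fluorine Added to a Cytotoxicity Series

The source may report more compounds than this note shows. Statements on the series, on what has been measured and on what is new or still open speak of the compounds shown alone.

Compound 1, `Cc1nnc(SCC(=O)N/N=c2/scc(-c3ccccc3)n2-c2ccccc2)s1`, was tested in a functional assay on C6 cells (Rattus norvegicus) for cytotoxicity, read by MTT assay, with a stated time of 24 h, tested at 100 ug/mL (on this read-out higher numbers stand for a weaker effect at the one concentration tested and lower numbers for a stronger effect), where compound 1 gives 61.8%. Among the compounds with values here, this is the higher of the two numbers measured so far, which on this read-out means the weaker effect. The other measured compound, compound 2, `O=C(CSc1nnnn1-c1ccccc1)N/N=c1/scc(-c2ccc(Br)cc2)n1-c1ccccc1`, gives 24.3% in this assay; it differs from compound 1 in more than one place, so the two numbers stand side by side without a counted step between them.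

Compound 3, `Cc1nnc(SCC(=O)N/N=c2/scc(-c3ccc(F)cc3)n2-c2ccccc2)s1`, has not yet been measured. It differs from compound 1 in a single place: fluoro in place of hydrogen on an aromatic carbon. Within the data shown here, no one-place step between measured compounds is available, so the size of this change must be judged from the change itself. The change is small, a single fluoro in place of hydrogen, and the step in this assay is expected to stay within the scatter, in no clear direction. Compound 3 is expected to give 57%, within 38% to 76%. The expected step is a number 4.8 percentage points lower from compound 1 to compound 3 (within the scatter).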

Compound 3, a percentage reported as activity, at one concentration (the size of the read-out at that concentration, not a potency): 34.9%
Compound 3: the middle estimate sits 22.1 percentage points above what was measured, outside the stated range (below it).
By their numbers in this assay, from the lowest: compound 2; then compound 3; then compound 1.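

In this assay, the change from phenyl to 4-fluorophenyl comes with a number 26.9 percentage points lower from compound 1 to compound 3 (beyond the scatter), which on this read-out means a stronger effect at the one concentration tested. Within the data shown here, this is the first step that can be read at a single place, and it shows that this position on the six-membered aromatic ring of carbon only responds even to a change of one heavy atom. Nothing shown here bears on why the fluoro has this effect.

On these data alone, it remains open whether this step is particular to fluoro, or whether a methoxy group or an amine in the same place would move the number in the same direction. As far as these compounds go, it is also open whether fluoro would have a similar effect on the other compound, whose structure differs in more than one place.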